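Methyl added at the ortho-tolyl urea of compound 1

This account rests on a few compounds, and the source may have more. Where it says the series, first, only, none or still open, it means among the compounds named here.

Measured so far in an ADME assay on the whole organism with Oryza sativa as the target, tested at 10 uM; a lower number here means a stronger effect, a higher number a weaker effect of the compound at the concentration tested:
compound 1, `Cc1ccccc1NC(=O)N[C@H](C)c1ccccc1`, gives 99%
compound 2, `Cc1ccccc1NC(=O)N[C@@H](C)c1ccccc1`, gives 99%
compound 3, `Cc1cccc(NC(=O)N[C@@H](C)c2ccccc2)c1`, gives 100%

Compound 1 stands level with compound 2, and compound 3 lies within the scatter of both. Going by the values given here, the only step between compounds that differ in one place is no change at the digits printed from compound 1 to compound 2 (within the scatter), which rests on (the fact that compounds 1 and 2 differ only in the configuration as drawn). Compound 4, `CCc1ccccc1NC(=O)N[C@H](C)c1ccccc1`, differs from compound 1 by methyl in place of hydrogen on a saturated chain carbon bound to an aromatic carbon. Among the compounds with values here, no measured step covers such an addition, so nothing among the three numbers speaks for a change. Compound 4 is therefore expected to sit close to compound 1, with a step of a number 1 percentage points lower from compound 1 to compound 4 (within the scatter) in this assay, and its estimated value is 98%, within 88% to 100%.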

Compound 4, a percentage reported as activity, at one concentration (the size of the read-out at that concentration, not a potency): 92%
The estimate for compound 4 lay 6 percentage points above the measured number; low and high end bracket the measured number.
By their numbers in this assay, from the lowest: compounds 4, 1, 2 and 3 (each within the scatter of the next).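

In this assay, going by these compounds alone, the change from methyl to ethyl, on a saturated chain carbon bound to an aromatic carbon, gives a number 7 percentage points lower from compound 1 to compound 4 (within the scatter) as the first measured step at this place. So this one added carbon does not move the read-out beyond the scatter of the assay. Nothing known here bears on this step or gives a cause for it.

The compounds shown leave open whether a longer chain such as propyl, or an amine or a carboxylic acid on this carbon, would give a step beyond the scatter. They also leave open whether the configuration as drawn would count with ethyl in place.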